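The source may hold more compounds than are shown below. What is called first, only, known or untested is meant among the compounds shown, and "the series" means these compounds.

Compound 1 `Cc1cc(NC(=S)Cn2nnc(-c3ccccc3)n2)n(C2CCCCC2)n1` gives 80% in an assay on HEK293 cells for activation of Kir3.1/Kir3.2 (Homo sapiens), read by thallium flux; on this read-out lower numbers stand for smaller maximal responses and higher numbers for larger maximal responses. Compound 2 `Cc1cc(NC(=O)Cn2nnc(-c3ccccc3)n2)n(-c2ccccc2)n1` gives 66% in this assay. Compound 3 `Cc1cc(NC(=O)Cn2nnc(-c3cccc(F)c3)n2)n(C2CCCCC2)n1` gives 96% in this assay.

Among the three measured compounds, compound 3 stands highest on the largest response reached, with compound 1 nearest, beyond the usual scatter, and compound 2 furthest, also beyond the scatter. Compound 4 `Cc1cc(NC(=O)Cn2nnc(-c3ccc(Cl)c(C)c3)n2)n(C2CCCCC2)n1` has not yet been measured. It differs from compound 3 in one place: 4-chloro-3-methylphenyl in place of 3-fluorophenyl on an aromatic carbon. Among the compounds with values here, no measured pair isolates this exchange, so its effect is open. The account expects a modest step downward, a number 11 percentage points lower from compound 3 to compound 4 (beyond the scatter), which may still fall within the scatter. Compound 4 is estimated at 85%, in a range from 60% to 100%.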

Compound 4, largest response reached (Emax), in percent of the reference or control that the assay uses: 89%
Beside the measured number, compound 4's estimate is 4 percentage points below it; the range from low to high includes it.
By their numbers in this assay, from the lowest: compound 2; then compounds 1, 4 and 3 (each within the scatter of the next, the first and the last beyond it).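

At the aromatic carbon of the five-membered ring with 4 nitrogen, 4-chloro-3-methylphenyl replaces 3-fluorophenyl with a number 7 percentage points lower from compound 3 to compound 4 (within the scatter) in this assay. This position therefore takes an aryl group of 8 heavy atoms rather than 7, with a different substitution, and the largest response stays within the scatter, a reading that rests on this single pair. Nothing measured here gives a reason for this result. From the compounds shown here alone, what the chloro and methyl groups each contribute alone stays open. So does whether a pyridyl ring or a carboxylic acid at this carbon would hold the response.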